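This account rests on a few compounds, and the source may have more. Where it says the series, first, only, none or still open, it means among the compounds named here.

Working notes on the series. Compound 1 `CCCCCCCCCCCC(=O)OC[C@H](CSC[C@@H](N)C(=O)NC(C)(C)CO)OC(=O)CCCCCCCCCCC` gives 15500 nM in an assay on HEK293 cells for agonist activity at Toll-like receptor 2 (Homo sapiens); a higher number here means that more compound is needed for the effect, a lower number that less compound is needed. Among the measured compounds shown here, compound 2 `CCCCCCCCCCCC(=O)OC[C@H](CSC[C@@H](N)C(=O)N[C@H](C)CO)OC(=O)CCCCCCCCCCC` gives 22200 nM in this assay, the highest of the two numbers so far; the step of a 1.4-fold higher number from compound 1 to compound 2 (0.16 log units; within the scatter) is within the scatter. Compound 3 `CCCCCCCCCCCC(=O)OC[C@H](CSC[C@@H](N)C(=O)NC1(CO)CC1)OC(=O)CCCCCCCCCCC` carries 1-(hydroxymethyl)cyclopropyl in place of 1-(hydroxymethyl)ethyl on an amide-type nitrogen. For the measured compounds named here, only the step from compound 1 to compound 2 bears on this change, and it was within the scatter, so no step beyond the scatter is expected in this assay in either direction; the expected step is a 1.2-fold lower number from compound 2 to compound 3 (0.09 log units; within the scatter). Compound 3 is therefore estimated at 18000 nM, with a range from 7000 nM to 45000 nM.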

Compound 3, half-maximal effective concentration: 265 nM
Estimate against measurement, compound 3: 68-fold (1.83 log units) above; the measured number lies below the stated range.
By their numbers in this assay, from the lowest: compound 3; then compounds 1 and 2 (each within the scatter of the next).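

With 1-(hydroxymethyl)cyclopropyl on the amide-type nitrogen, this assay shows an 84-fold lower number from compound 2 to compound 3 (1.92 log units; beyond the scatter) and also a 58-fold lower number from compound 1 to compound 3 (1.77 log units; beyond the scatter), so this position can respond strongly to the substituent. The earlier exchange between the two groups without a ring did not reveal this sensitivity, and here the large step comes only with the three-membered ring. No measurement at hand explains the step. Going by these compounds, whether cyclobutyl in place of cyclopropyl preserves the step remains open, as does whether the ring still gives it with an amine or a carboxylic acid in place of the hydroxymethyl group.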